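The compounds below may be only part of what the source reports. "The series", "measured", "known", "first", "only" and "open" are said of these compounds alone.

Among the compounds with values here, compound 2, with the structure `CNC(=O)N1CCCc2ccc(NC(=O)c3ccc(-c4ccccc4)cc3)cc21`, is the weakest of the three compounds measured so far. In a functional assay on MV4-11 cells (Homo sapiens) for antiproliferative activity, with a stated time of 6 days, tested at 1.56 uM (on this read-out lower numbers stand for a weaker effect and higher numbers for a stronger effect at the one concentration tested), compound 2 gives 19.7%. Its nearest neighbour on this read-out is compound 3, the structure `CNC(=O)N1CCCc2ccc(NC(=O)c3cccc(-c4ccn(C)n4)c3)cc21`, which in this assay gives 70.5%; furthest away stands compound 1, the structure `CNC(=O)N1CCCc2ccc(NC(=O)c3ccc(-c4cc[nH]n4)cc3)cc21`, which in this assay gives 92.5%.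

The compound now under consideration is compound 4, with the structure `CNC(=O)N1CCCc2ccc(NC(=O)c3ccc(-c4ccn(C)n4)cc3)cc21`. Compared with compound 2 it carries 1-methyl-1H-pyrazol-3-yl in place of phenyl on an aromatic carbon, on an aromatic carbon of a six-membered aromatic ring of carbon only, para to a large group.

Within the data shown here, one measured step bears directly on this change: a number 72.8 percentage points lower from compound 1 to compound 2 (beyond the scatter), a large drop when the phenyl replaced the 1H-pyrazol-3-yl on that same carbon. The change from compound 2 to compound 4 runs the other way, putting a pyrazole back at the same place, though now as its 1-methyl form. Compound 3, which carries the same 1-methyl-1H-pyrazol-3-yl elsewhere on the ring, is also well above compound 2. Compound 4 is therefore expected to regain most of that lost inhibition, with a step of a number 60.3 percentage points higher from compound 2 to compound 4 (beyond the scatter) in this assay. The estimate for compound 4 is 80%, within a range from 55% to 95%.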

Compound 4, a percentage reported as inhibition, at one concentration (the size of the read-out at that concentration, not a potency): 72.2%
Beside the measured number, compound 4's estimate is 7.8 percentage points above it, within the range that was stated.
By their numbers in this assay, from the lowest: compound 2; then compounds 3 and 4 (each within the scatter of the next); then compound 1.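

In this assay, the step of a number 52.5 percentage points higher from compound 2 to compound 4 (beyond the scatter) shows that the large gain over phenyl on this aromatic carbon, para to a large group, does not depend on the hydrogen on the pyrazole nitrogen, since 1-methyl-1H-pyrazol-3-yl has 0 hydrogen-bond donors, as phenyl does, and differs from it in carrying 2 hydrogen-bond acceptors. The methyl on that aromatic nitrogen is still not free of cost, as the step of a number 20.3 percentage points lower from compound 1 to compound 4 (beyond the scatter) is modest but beyond the scatter, so the unsubstituted pyrazole keeps an edge at this position. No measurement at hand explains either step.

The compounds shown leave open whether a ring with a single nitrogen, such as a pyridyl group, would bring the same gain at this carbon, and whether a chain longer than methyl, such as ethyl or propyl, on the pyrazole nitrogen would cost more. Since each number is a reading at one concentration, they also leave open whether the stronger and weaker effects seen at that concentration would compare in the same way at any other concentration.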